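Returning the Methoxy-Bearing Ring to the Benzyl Arm

The source may report more compounds than this note shows. Statements on the series, on what has been measured and on what is new or still open speak of the compounds shown alone.

Compound 2 `COc1cc(N(Cc2ccc(F)cc2)C(=O)CSc2nc3ccccc3s2)cc(OC)c1OC` stands at the top of the three numbers in a functional assay on PC-3 cells (Homo sapiens) for antiproliferative activity, read by MTT assay, with a stated time of 48 h (on this read-out higher numbers stand for weaker inhibition and lower numbers for stronger inhibition), giving 50800 nM. Compound 1 `COc1ccc(CN(C(=O)CSc2nc3ccccc3s2)c2cc(OC)c(OC)c(OC)c2)cc1F` gives 20100 nM, and compound 3 `COc1ccc(CN(C(=O)CSc2nc3cc(Br)ccc3s2)c2cc(OC)c(OC)c(OC)c2)cc1O` gives 8210 nM. Compound 4 `COc1ccc(CN(C(=O)CSc2nc3ccccc3s2)c2cc(OC)c(OC)c(OC)c2)cc1N` carries 3-amino-4-methoxyphenyl in place of 4-fluorophenyl on a saturated chain carbon bound to an amide-type nitrogen. For the measured compounds named here, the one measured step that bears on this change is a 2.5-fold higher number from compound 1 to compound 2 (0.40 log units; beyond the scatter), which moved in the opposite direction, from a methoxy-bearing ring to plain fluorophenyl, and raised the number modestly. Compound 3 differs from compound 2 in more than one place, so its value guides only loosely. Compound 4 is therefore expected to show a lower number, a step of about a 3.2-fold lower number from compound 2 to compound 4 (0.50 log units; beyond the scatter). Compound 4 is estimated at 16000 nM, within a range from 6000 nM to 42000 nM.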

Compound 4, half-maximal inhibitory concentration: 7510 nM
Estimate against measurement, compound 4: 2.1-fold (0.33 log units) above; the range from low to high includes it.
By their numbers in this assay, from the lowest: compounds 4 and 3 (each within the scatter of the next); then compound 1; then compound 2.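

In this assay, the full change to the 3-amino-4-methoxyphenyl ring gives a 6.8-fold lower number from compound 2 to compound 4 (0.83 log units; beyond the scatter), so this position can shift the number further than the earlier step showed. For the compounds shown here, changing only one group, amino in place of fluoro on an aromatic carbon, gives a 2.7-fold lower number from compound 1 to compound 4 (0.43 log units; beyond the scatter), so the methoxy-bearing ring alone does not account for the whole drop. Nothing available explains why the amino group has this effect. Going by these compounds, whether an acetamido or dimethylamino group in its place would hold the number at this level remains open.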